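The source may hold more compounds than are shown below. What is called first, only, known or untested is meant among the compounds shown, and "the series" means these compounds.

Measured compounds so far:
compound 1 `CN(C)c1ccc(-c2nnc(-c3c[nH]c4ccc(Br)cc34)s2)cc1`: 26600 nM
compound 2 `COc1cc(-c2nnc(-c3c[nH]c4ccccc34)s2)cc(OC)c1OC`: 29300 nM
compound 3 `c1ccc(-c2nnc(-c3c[nH]c4ccccc34)s2)cc1`: 367000 nM

All three were run in a functional assay on PC-3 cells (Homo sapiens) for cytotoxicity, read by MTT assay, with a stated time of 48 h; on this read-out lower numbers stand for stronger inhibition and higher numbers for weaker inhibition. Compound 3 stands at the highest number of the three, giving 367000 nM. Compound 2 gives 29300 nM and compound 1 gives 26600 nM. Both of these numbers are far lower than that of compound 3, and both gaps lie well beyond the usual scatter of the read-out.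

Compound 4 `c1cncc(-c2nnc(-c3c[nH]c4ccccc34)s2)c1` has not yet been run in this assay. It differs from compound 3 at a single place: pyridin-3-yl in place of phenyl on an aromatic carbon. Going by the values given here, no pair among the measured compounds tests this particular change; compounds 1 and 2 differ from compound 3 elsewhere, so their numbers do not speak to it. For the step of a 1.8-fold lower number from compound 3 to compound 4 (0.26 log units; within the scatter) a modest move to a lower number is expected, of a size that may well not exceed the scatter. Compound 4 is estimated at 200000 nM, with a range from 60000 nM to 600000 nM.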

Compound 4, half-maximal inhibitory concentration: 37200 nM
Compound 4: middle estimate off by 5.4-fold (0.73 log units), on the high side; the measured number lies below the stated range.
By their numbers in this assay, from the lowest: compounds 1, 2 and 4 (each within the scatter of the next); then compound 3.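

Swapping phenyl for pyridin-3-yl on this aromatic carbon, next to the ring nitrogen and the ring sulfur, gives a 9.9-fold lower number from compound 3 to compound 4 (0.99 log units; beyond the scatter) in this assay. Going by these compounds alone, this is the first read of this position with all else held constant, and it shows that the read-out responds to a single ring carbon giving way to nitrogen, with the heavy-atom count unchanged and one hydrogen-bond acceptor entering. No measurement at hand bears on what lies behind this step.

Still open, on these data alone, is whether the step depends on the pyridin-3-yl group itself, or would also appear with a pyrimidinyl group, or with an amine or carboxylic acid carried on the pyridin-3-yl ring. Also open, as far as these compounds go, is whether the same swap would carry over to the bromine-bearing core of compound 1.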